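The source may report more compounds than this note shows. Statements on the series, on what has been measured and on what is new or still open speak of the compounds shown alone.

The series rests on a symmetric diarylguanidine, compound 1 `N=C(Nc1cccc2ccccc12)Nc1cccc2ccccc12`, which in an assay on membranes from brain (Cavia porcellus) for binding affinity to Sigma non-opioid intracellular receptor 1 (Homo sapiens), read by radioligand binding (on this read-out lower numbers stand for stronger inhibition and higher numbers for weaker inhibition), gives 165 nM. Its single-methyl analogue, compound 2 `CN(C(=N)Nc1cccc2ccccc12)c1cccc2ccccc12`, gives 4800 nM in this assay. Among the compounds with values here, that one step, a 29-fold higher number from compound 1 to compound 2 (1.46 log units; beyond the scatter), is the only measured step in the set, and it leaves compound 2 as the highest of the two numbers, with compound 1 the nearest point.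

Compound 3 `CN(C(=N)N(C)c1cccc2ccccc12)c1cccc2ccccc12` is not yet measured. It differs from compound 2 by methyl in place of hydrogen on a nitrogen on an aromatic ring, so that both nitrogens bearing an aromatic ring now carry a methyl group. Within the data shown here, the only comparison that bears on this change is the step from compound 1 to compound 2, where the same substitution on the other nitrogen gave a large rise in the number, well beyond the scatter. Repeating it a second time is therefore expected to push the number further up, though the size of a second step cannot be read from one example. On that basis compound 3 is expected at 12000 nM in this assay, within a range of 3000 nM to 50000 nM, which means an estimated step of a 2.5-fold higher number from compound 2 to compound 3 (0.40 log units; beyond the scatter).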

Compound 3, half-maximal inhibitory concentration: 10700 nM
Compound 3: the middle estimate sits 1.1-fold (0.05 log units) above what was measured; the range from low to high includes it.
By their numbers in this assay, from the lowest: compound 1; then compound 2; then compound 3.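

In this assay, methyl in place of hydrogen on a nitrogen on an aromatic ring raises the number a second time, giving a 2.2-fold higher number from compound 2 to compound 3 (0.35 log units; beyond the scatter), so both steps of this kind among the three compounds point the same way and none goes against them. The second step is rated modest, while the first, a 29-fold higher number from compound 1 to compound 2 (1.46 log units; beyond the scatter), is rated large, which shows that the change does not repeat at the same size once the other nitrogen on an aromatic ring already carries a methyl group, although this rests on a single pair of steps. Nothing measured here accounts for the direction of either step or for the difference in their sizes.

The compounds shown leave open whether the rise belongs to methyl in particular or would also follow a longer chain such as ethyl, or a group such as a carboxylic acid or an amine, at this place. They also leave open whether any replacement for hydrogen on these nitrogens could lower the number below that of compound 1, 165 nM.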